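A few compounds are considered here, and "the series" means these few. Any claim that something is new, unique, unknown or untested is made for them only; others in the source may bear on it.

The measured compounds so far:
compound 1 `O=C(/C=C/c1cccc(NC(=O)c2ccccc2Br)c1)c1nc2ccccc2[nH]1`, 1680 nM in a functional assay on HCT-116 cells (Homo sapiens) for antiproliferative activity, read by MTT assay, with a stated time of 48 h; a higher number here means a weaker inhibitor, a lower number a stronger inhibitor
compound 2 `O=C(/C=C/c1cccc(NS(=O)(=O)c2ccc(Cl)cc2)c1)c1nc2ccccc2[nH]1`, 1960 nM in this assay

Among the measured compounds shown here, compound 2 stands at the highest of the two numbers, but its only neighbour, compound 1, sits within the scatter of it: the step of a 1.2-fold higher number from compound 1 to compound 2 (0.07 log units; within the scatter) changed almost nothing. The next compound, compound 3 `Cc1cc(C)cc(S(=O)(=O)Nc2cccc(/C=C/C(=O)c3nc4ccccc4[nH]3)c2)c1`, differs from compound 2 as follows.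

3,5-dimethylphenyl in place of 4-chlorophenyl on a sulfonyl sulfur

For the measured compounds named here, only one measured step bears on this change, a 1.2-fold higher number from compound 1 to compound 2 (0.07 log units; within the scatter), which exchanged the whole group on the ring nitrogen and stayed within the scatter. Going by the values given here, no measured step varies the aryl on the sulfonyl sulfur itself. The account therefore expects a step of about the size a 1.0-fold higher number from compound 2 to compound 3 (0.01 log units; within the scatter), that is, nothing beyond the scatter. For compound 3 the estimated value is 2000 nM, with a range from 900 nM to 4500 nM.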

Compound 3, half-maximal inhibitory concentration: 1220 nM
For compound 3 the middle estimate is 1.6-fold (0.21 log units) above the measured one; low and high end bracket the measured number.
By their numbers in this assay, from the lowest: compounds 3, 1 and 2 (each within the scatter of the next).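

In this assay, among the compounds shown here, the aryl on the sulfonyl sulfur is varied on its own for the first time, and the step, a 1.6-fold lower number from compound 2 to compound 3 (0.21 log units; within the scatter), stays inside the usual scatter. Compound 1 and compound 2 could not show this, as they differ in the whole group on the nitrogen, whereas here 4-chlorophenyl and 3,5-dimethylphenyl on a sulfonyl sulfur cannot be told apart in this read-out. No measured evidence bears on why these two groups read alike.

The compounds shown leave open whether a group other than a substituted phenyl, such as a pyridine ring or a plain methyl, would also stay within the scatter at this position. They also leave open whether an amine or a carboxylic acid on that phenyl ring would move the number beyond it.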